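The source may hold more compounds than are shown below. What is called first, only, known or untested is meant among the compounds shown, and "the series" means these compounds.

Compound 1 `ClCc1ccccc1Cn1cnc2c(Cl)nc(Cl)nc21` gives 1820 nM in a functional assay on UACC-257 cells (Homo sapiens) for cytotoxicity, read by sulforhodamine B assay, with a stated time of 48 h; a lower number here means a stronger inhibitor of growth, a higher number a weaker inhibitor of growth. Compound 2 `ClCc1cccc(Cn2cnc3c(Cl)nc(Cl)nc32)c1` gives 1860 nM in this assay. Compound 3 `Nc1nc(Cl)c2ncn(Cc3ccccc3CCl)c2n1` gives 13200 nM in this assay.

Compounds 1 and 2 share the same atoms joined differently; the difference between the two cores is not broken down here, and their two values lie within the scatter of each other. Compound 3 is compound 1 with one change, (amino in place of chloro on an aromatic carbon). That change made a step of a 7.3-fold higher number from compound 1 to compound 3 (0.86 log units; beyond the scatter), a weakening of growth inhibition that goes beyond the scatter.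

Compound 4 `Nc1nc(Cl)c2ncn(Cc3cccc(CCl)c3)c2n1` has not yet been measured. It is compound 2 with the same change, (amino in place of chloro on an aromatic carbon), at a place described in the same words as for compound 3. For the measured compounds named here, with only one measured example of this change, the expectation rests on that single step.

Compound 4 is expected to follow the step from compound 1 to compound 3, with an estimated step of a 7.0-fold higher number from compound 2 to compound 4 (0.84 log units; beyond the scatter) because a 7.3-fold higher number from compound 1 to compound 3 (0.86 log units; beyond the scatter) was seen for the same change. Compound 4 is therefore estimated at 13000 nM in this assay, with a likely range of 6000 nM to 28000 nM.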

Compound 4, concentration for 50% growth inhibition: 5750 nM
Compound 4: the middle estimate sits 2.3-fold (0.35 log units) above what was measured, and the stated range ends above it.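

Replacing chloro with amino on an aromatic carbon weakened growth inhibition on the second core as well, in this assay, with a 3.1-fold higher number from compound 2 to compound 4 (0.49 log units; beyond the scatter). Set beside the earlier step, this one points the same way, and the two sizes cannot be told apart: the same change on two cores in this assay, a 7.3-fold higher number (0.86 log units; beyond the scatter) from compound 1 to compound 3 and a 3.1-fold higher number (0.49 log units; beyond the scatter) from compound 2 to compound 4, 2.3-fold (0.37 log units) apart, within the scatter of two such steps. This shows that, for these two pairs, the change carried from one core to the other in direction and in a size that agrees within the scatter, but two pairs in one assay do not establish a rule for other cores, and they do not explain why the amino compounds are weaker.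

Among the compounds shown, only chloro and amino stand at this place, so it remains open how a methoxy group or a dimethylamino group would behave there. All the values also come from a single assay on one cell line, so whether the step holds in other cells remains an open question.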